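This account rests on a few compounds, and the source may have more. Where it says the series, first, only, none or still open, it means among the compounds named here.

Measured so far: compound 1 `COCC(COC)N(C)c1nc(C)nc2c1nnn2-c1ccc(C(C)C)cc1Br` with 21.3 nM and compound 2 `CCN(c1nc(C)nc2c1nnn2-c1ccc(C(C)C)cc1Br)C(COC)COC` with 123 nM in an in vitro assay on 293-EBNA cells for binding affinity to corticotropin-releasing factor receptor 1 (Homo sapiens); a lower number here means a stronger inhibitor, a higher number a weaker inhibitor.

Compound 2 stands highest of the two numbers; its nearest neighbour is compound 1, which gives 21.3 nM. Compound 3 `CCCC(CN(C)C)Nc1nc(C)nc2c1nnn2-c1ccc(C(C)C)cc1Br` carries a group of 9 heavy atoms (7 carbon, 2 nitrogen; no ring) in place of a group of 10 heavy atoms (7 carbon, 1 nitrogen, 2 oxygen; no ring), on an aromatic carbon. Among the compounds with values here, the one measured step that touches this nitrogen, a 5.8-fold higher number from compound 1 to compound 2 (0.76 log units; beyond the scatter), shows that what hangs on it shifts the number beyond the scatter. Within the data shown here, the new chain and the freed hydrogen on the nitrogen have no measured precedent here, so the direction rests on that single step. Compound 3 is therefore expected at 40 nM, within 10 nM to 160 nM, a step of a 3.1-fold lower number from compound 2 to compound 3 (0.49 log units; beyond the scatter).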

Compound 3, inhibition constant: 38.7 nM
For compound 3 the middle estimate is 1.0-fold (0.01 log units) above the measured one; low and high end bracket the measured number.
By their numbers in this assay, from the lowest: compounds 1 and 3 (each within the scatter of the next); then compound 2.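

At this aromatic carbon, the group of 9 heavy atoms (7 carbon, 2 nitrogen), with its 1 hydrogen-bond donor, improves on the oxygen-bearing group in this assay (a 3.2-fold lower number from compound 2 to compound 3 (0.50 log units; beyond the scatter)). A second comparison shows no real difference (a 1.8-fold higher number from compound 1 to compound 3 (0.26 log units; within the scatter)), so among these compounds the oxygen atoms are not needed to reach a low number. Nothing measured here explains these shifts.

The new chain and the hydrogen on the linking nitrogen changed together, so their shares cannot be separated. As far as these compounds go, how a longer chain or a piperidine ring would fare at this position remains open.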